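A few compounds are considered here, and "the series" means these few. Any claim that something is new, unique, unknown or untested is made for them only; others in the source may bear on it.

In a physicochemical assay for solubility (on this read-out lower numbers stand for lower solubility and higher numbers for higher solubility), compound 3 `CNC(=O)c1cc(C(=O)NC(C)C)cn(Cc2ccccc2)c1=O` gives >= 136 ug/mL, which is a limit and not a number. Compound 1 `CNC(=O)c1cc(C(=O)NC2CCOCC2)cn(Cc2ccccc2)c1=O` gives >= 174 ug/mL, also a limit. Among the measured compounds shown here, compound 2 `CNC(=O)c1cccn(Cc2ccccc2)c1=O` gives 78 ug/mL, the only true number of the three.

Compound 4 `CNC(=O)c1cc(C(=O)NCCC(C)C)cn(Cc2ccccc2)c1=O` differs from compound 3 by one change, isopentyl in place of isopropyl on an amide-type nitrogen.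

For the measured compounds named here, three measured steps bear on this amide. Losing the (oxan-4-yl)carbamoyl group gave an at least 2.2-fold lower number from compound 1 to compound 2 (0.34 log units; beyond the scatter). Adding isopropylcarbamoyl gave an at least 1.7-fold higher number from compound 2 to compound 3 (0.24 log units; that floor lies within the scatter). Both show what happens when the whole group is absent, not what the chain on its nitrogen does. The closest case, a swap on that same nitrogen, is a step that the two limits leave unreadable from compound 1 to compound 3, so no measured size exists for a change of this kind.

The expectation therefore rests on the structural change alone, and it is for a modest step down in this assay, with a wide margin. The low side is anchored by compound 2 at 78 ug/mL, which has no such amide at all. The expected move is an at least 1.3-fold lower number from compound 3 to compound 4 (0.13 log units; that floor lies within the scatter). For compound 4 the estimated value is 100 ug/mL, with an expected range of 40 ug/mL to 200 ug/mL.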

Compound 4, solubility: 10 ug/mL
Beside the measured number, compound 4's estimate is 10-fold (1.00 log units) above it, and the stated range ends above it.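

On the amide-type nitrogen the chain matters strongly in this assay: isopentyl in place of isopropyl gives an at least 13-fold lower number from compound 3 to compound 4 (1.13 log units; beyond the scatter), and isopentyl in place of oxan-4-yl gives an at least 17-fold lower number from compound 1 to compound 4 (1.24 log units; beyond the scatter). The carbamoyl group therefore brings no rise in this read-out by itself, since with isopentyl on its nitrogen the step is a 7.8-fold lower number from compound 2 to compound 4 (0.89 log units; beyond the scatter), so compound 4 falls beyond the scatter from compound 2, which has no such amide. The size of the isopropyl-to-isopentyl step is only a floor because compound 3 carries a limit and not a number: the limit of >= 136 ug/mL in this assay, at which 1 of the 4 values shown sits.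

Still open, on these data alone, is whether the fall follows the count of chain carbons or the branched end of the isopentyl group, a question that a straight butyl chain or a longer chain on the same nitrogen would address. Also open, as far as these compounds go, is whether an amine or a carboxylic acid at the end of such a chain would keep the longer reach without the fall, and how isopropyl and oxan-4-yl rank against each other on this nitrogen.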